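A few compounds are considered here, and "the series" means these few. Any claim that something is new, unique, unknown or untested is made for them only; others in the source may bear on it.

Measured compounds in an ADME assay on Vero cells (Chlorocebus sabaeus) for cytotoxicity, read by MTT assay, with a stated time of 72 h; on this read-out lower numbers stand for stronger inhibition and higher numbers for weaker inhibition:
compound 1 `O=C(NNC(=O)c1cc([N+](=O)[O-])c[nH]1)Nc1ccc(Br)cc1`: 378000 nM
compound 2 `Cc1ccccc1NC(=S)NNC(=O)c1cc([N+](=O)[O-])c[nH]1`: 462000 nM
compound 3 `O=C(NNC(=O)c1cc([N+](=O)[O-])c[nH]1)Nc1ccc([N+](=O)[O-])cc1`: 211000 nM

Among the compounds with values here, compound 3 gives the lowest of the three numbers, but its gap to compound 1 is within the scatter; only the gap to compound 2 lies beyond it, and for that pair no single-change step is defined, so the two values stand on their own.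

Within the data shown here, the one defined step runs a 1.8-fold lower number from compound 1 to compound 3 (0.25 log units; within the scatter), a change on the aryl ring that leaves the read-out essentially where it was.

Compound 4 `Cn1cc([N+](=O)[O-])cc1C(=O)NNC(=O)Nc1ccc([N+](=O)[O-])cc1` differs from compound 3 by methyl in place of hydrogen on an aromatic nitrogen. Among the measured compounds shown here, no measured pair in this set touches the ring nitrogen of the shared core, so the step from compound 1 to compound 3 bears on it only as a general sign that single changes at the periphery have so far moved the numbers little.

For compound 4 a step of a 1.2-fold higher number from compound 3 to compound 4 (0.07 log units; within the scatter) is therefore expected, that is no change beyond the scatter. The estimate for compound 4 in this assay is 250000 nM, with a range from 100000 nM to 600000 nM.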

Compound 4, half-maximal inhibitory concentration: 402000 nM
Estimate against measurement, compound 4: 1.6-fold (0.21 log units) below, and the stated range covers the measured number.
By their numbers in this assay, from the lowest: compounds 3, 1, 4 and 2 (each within the scatter of the next, the first and the last beyond it).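

In this assay the ring nitrogen of the shared core now has a measured single change: methyl in place of hydrogen on this aromatic nitrogen gives a 1.9-fold higher number from compound 3 to compound 4 (0.28 log units; within the scatter), so the two compounds stand within the scatter of each other. The series thus gains its first step on the core itself, at a position two ring bonds from the ring atom that bears a nitro group, and this step, like the earlier one on the aryl ring, stays within the scatter. No independent measurement is available to explain this result.

This nitrogen is tested with methyl only and only with the nitro-substituted aryl ring of compound 3. On these data alone, how a longer chain, such as ethyl, or a chain ending in an amine or a carboxylic acid would read at this nitrogen remains open.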